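The compounds below may be only part of what the source reports. "The series", "measured", "known", "first", "only" and "open" are said of these compounds alone.

Compound 1 `CC(C)Oc1nc(C(C)(C)C)ccc1CNC(=O)C(C)c1ccc(NS(C)(=O)=O)c(F)c1` gives 2.3 nM in an assay on cells for antagonist activity at transient receptor potential cation channel subfamily V member 1 (Homo sapiens), read by FLIPR and calcium flux, with a stated time of 6 min; a lower number here means a stronger inhibitor, a higher number a weaker inhibitor.
Compound 2 `CCOCCOc1nc(C(C)(C)C)ccc1CNC(=O)C(C)c1ccc(NS(C)(=O)=O)c(F)c1` gives 23.9 nM in this assay.

Within the data shown here, of the two numbers measured so far, compound 2 stands at the higher, that is the weaker, end; compound 1 is the only neighbour, and the single step between them is a 10-fold higher number from compound 1 to compound 2 (1.02 log units; beyond the scatter). That step changed only the group attached through oxygen on the shared core, and it shows that this position responds strongly to what is put there.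

Compound 3 `CCCCCc1nc(C(C)(C)C)ccc1CNC(=O)C(C)c1ccc(NS(C)(=O)=O)c(F)c1` has not yet been measured. It differs from compound 2 in one place: pentyl in place of 2-ethoxyethoxy on an aromatic carbon. The 2-ethoxyethoxy group leaves and a pentyl chain enters. Among the measured compounds shown here, the only measured step bears on this change indirectly, since it compared two groups that were both attached through oxygen, and neither was a plain chain. It tells that a change here can easily be large, but not in which direction a pentyl chain would move the number.

Compound 3 is therefore expected to give 8 nM in this assay, with a wide range from 2 nM to 40 nM. This expectation amounts to a 3.0-fold lower number from compound 2 to compound 3 (0.48 log units; beyond the scatter), a modest gain with much uncertainty.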

Compound 3, inhibition constant: 1.9 nM
Compound 3: the middle estimate sits 4.2-fold (0.62 log units) above what was measured, outside the stated range (below it).
By their numbers in this assay, from the lowest: compounds 3 and 1 (each within the scatter of the next); then compound 2.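

In this assay the move from 2-ethoxyethoxy to pentyl gives a 13-fold lower number from compound 2 to compound 3 (1.10 log units; beyond the scatter) and so shows that this position, on an aromatic carbon next to the ring nitrogen, can carry a plain carbon chain with no oxygen at all and still reach a low number. The second new step, a 1.2-fold lower number from compound 1 to compound 3 (0.08 log units; within the scatter) and within the scatter, puts pentyl and isopropoxy level, so in this pair an oxygen joining the group to the shared core is not needed for a low number, and the earlier 2-ethoxyethoxy result now looks like a feature of that one group rather than of every group at this position. No separate measurement bears on why 2-ethoxyethoxy stands apart from the other two groups.

Still open, as far as these compounds go, is whether the higher number of compound 2 goes with the oxygen inside its chain or with the chain's shape, a question that a butoxy group could help to settle. A longer chain such as octyl, or a pentyl chain ending in an amine or a carboxylic acid, would show how much more this position accepts.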